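The source may hold more compounds than are shown below. What is called first, only, known or untested is meant among the compounds shown, and "the series" means these compounds.

Of the compounds shown here, two built on a shared core have been measured in a functional assay on MDA-MB-468 cells (Homo sapiens) for cytotoxicity, read by sulforhodamine B assay, with a stated time of 48 h, tested at 100 nM; on this read-out higher numbers stand for a weaker effect at the one concentration tested and lower numbers for a stronger effect. Compound 1 `COc1cc(C)cc(-c2c(-c3ccnc(-c4ccc(C(C)=O)cc4)c3)cnn2CC#N)c1` gives 68%, the higher of the two numbers and so the weaker effect. Compound 2 `COc1cc(C)cc(-c2nn(CC#N)cc2-c2ccc(-c3cccc(C(C)=O)c3)nc2)c1` gives 9%, a number beyond the scatter below that of compound 1. Compound 3 `COc1cc(C)cc(-c2c(-c3ccnc(-c4ccc(N(C)C)cc4)c3)cnn2CC#N)c1` differs from compound 1 by dimethylamino in place of acetyl on an aromatic carbon. Within the data shown here, no measured pair shows this change, so its effect in this assay is unknown. The step is expected to be small, none beyond the scatter, as a number 6 percentage points lower from compound 1 to compound 3 (within the scatter). Compound 3 is estimated at 62%, between 25% and 95%.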

Compound 3, a percentage reported as activity, at one concentration (the size of the read-out at that concentration, not a potency): -50%
Estimate against measurement, compound 3: 112 percentage points above; measured number below the stated range.
By their numbers in this assay, from the lowest: compound 3; then compound 2; then compound 1.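

In this assay, dimethylamino in place of acetyl on this aromatic carbon gives a number 118 percentage points lower from compound 1 to compound 3 (beyond the scatter), so this position of the 4-acetylphenyl group responds strongly to the group it carries. The change is large even though both groups have the same counts of heavy atoms, hydrogen-bond donors and hydrogen-bond acceptors, so those counts do not predict the step here. Nothing measured here accounts for the size of this step. On these data alone, whether a primary amine, a methoxy group or diethylamino at this position would give a similar number remains open. So does whether dimethylamino would have a similar effect on the core of compound 2.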